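Chain shortening on the aryl ether of compound 1

The source may report more compounds than this note shows. Statements on the series, on what has been measured and on what is new or still open speak of the compounds shown alone.

For the measured compounds named here, compound 1 `O=C(O)CCCOc1ccc2nc(-c3cn(-c4ccc(O)c(F)c4)nn3)ccc2c1` is one of two compounds measured in a physicochemical assay for solubility, read by spectrophotometry, using the shake flask method, with a stated time of 48 h, at pH 6.5; a higher number here means a more soluble compound, a lower number a less soluble compound. In this assay compound 1 gives 19.2 ug/mL, the higher of the two numbers. Going by the values given here, compound 2 `NCCOc1ccc2nc(-c3cn(-c4ccc(O)cc4)nn3)ccc2c1`, which carries a different chain on the ether oxygen and no fluorine on the phenol ring, gives in this assay 3.7 ug/mL; the gap between compound 1 and compound 2 lies beyond the usual scatter, though no single-point step connects the two structures.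

Compound 3 `O=C(O)COc1ccc2nc(-c3cn(-c4ccc(O)c(F)c4)nn3)ccc2c1` is not yet measured. It differs from compound 1 in one place: carboxy in place of 2-carboxyethyl on a saturated chain carbon bound to an oxygen on an aromatic ring. Read one bond further out, the 3-carboxypropoxy chain becomes carboxymethoxy; the acid group itself, with its one donor and one acceptor, is kept.

Among the compounds with values here, no measured pair isolates this change, so the expected step is small. Compound 3 is expected to give a number close to that of compound 1, with the step of a 1.3-fold higher number from compound 1 to compound 3 (0.11 log units; within the scatter) most likely within the scatter. The estimate for compound 3 is 25 ug/mL, in the range 10 ug/mL to 60 ug/mL.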

Compound 3, solubility: 37 ug/mL
Compound 3: middle estimate off by 1.5-fold (0.17 log units), on the low side; the measured number falls inside the stated range.
By their numbers in this assay, from the lowest: compound 2; then compounds 1 and 3 (each within the scatter of the next).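

For the compounds shown here, the step of a 1.9-fold higher number from compound 1 to compound 3 (0.28 log units; within the scatter) in this assay is the first one that isolates a change in a single place, carboxy in place of 2-carboxyethyl on a saturated chain carbon bound to an oxygen on an aromatic ring. With the acid group kept, the 3-carboxypropoxy and carboxymethoxy chains are not separated by this read-out, so over these two chains the number does not depend measurably on the change. Nothing measured among these compounds bears on why the two chains read alike.

From the compounds shown here alone, whether this holds for a longer chain than 3-carboxypropoxy, or for an amine or a primary amide in place of the carboxylic acid with the rest of compound 3 kept, stays open, and compound 2 cannot settle it, as it differs from compound 1 in more than one place. The part played by the fluorine on the phenol ring also stays open, as the compounds shown hold no pair that differs there alone.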